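The source may report more compounds than this note shows. Statements on the series, on what has been measured and on what is new or still open speak of the compounds shown alone.

Compound 1 `COc1cc(NC(C)CCCNC(=O)NNC(=O)Nc2ccc(Cl)cc2)c2ncccc2c1`: 186000 nM
Compound 2 `COc1cc(NC(C)CCCNC(=O)Nc2ccc(F)cc2)c2ncccc2c1`: 24000 nM
Compound 3 `COc1cc(NC(C)CCCNC(=O)NNC(=O)Nc2ccc(Br)cc2)c2ncccc2c1`: 209000 nM

All three values come from a functional assay on MOLT-4 cells (Homo sapiens) for inhibition, read by MTT assay, with a stated time of 72 h; on this read-out higher numbers stand for weaker inhibition and lower numbers for stronger inhibition. There, compound 3 at 209000 nM cannot be told apart from compound 1, while compound 2 has a clearly lower number.

The next compound to be measured is compound 4 `COc1cc(NC(C)CCCNC(=O)NNC(=O)Nc2cccc(F)c2)c2ncccc2c1`. It carries 3-fluorophenyl in place of 4-bromophenyl on an amide-type nitrogen. The closest measured comparison is the exchange of chloro for bromo, a 1.1-fold higher number from compound 1 to compound 3 (0.05 log units; within the scatter), which shows that this one change of halogen made no measurable difference. The two larger steps, a 7.8-fold lower number from compound 1 to compound 2 (0.89 log units; beyond the scatter) and an 8.7-fold higher number from compound 2 to compound 3 (0.94 log units; beyond the scatter), exchange the whole ((4-bromophenyl)carbamoyl)amino or ((4-chlorophenyl)carbamoyl)amino group for 4-fluorophenyl. Compound 4 keeps the ((3-fluorophenyl)carbamoyl)amino form, so those two steps bear on it only weakly. Among the compounds with values here, no measured compound carries 3-fluorophenyl, which leaves the estimate uncertain.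

In this assay, the expected change is therefore small, an estimated 1.2-fold lower number from compound 3 to compound 4 (0.09 log units; within the scatter), and not expected to go beyond the scatter. For compound 4 the estimated value is 170000 nM, with an expected range from 80000 nM to 320000 nM.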

Compound 4, half-maximal inhibitory concentration: >= 250000 nM
Compound 4: a limit, no number (the forecaster's own chance of this, stated with the estimate: 10%); middle value at least 1.4-fold (0.16 log units) away from the limit.
By their numbers in this assay, from the lowest: compound 2; then compounds 1 and 3 (each within the scatter of the next). At a limit, above all of these: compound 4.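

In this assay compound 4 ends at a limit of the assay, not at a number: the limit of >= 250000 nM in this assay, at which 1 of the 4 values shown sits. On the amide-type nitrogen, the change to 3-fluorophenyl can therefore be read only as a floor, an at least 1.1-fold higher number from compound 3 to compound 4 (0.07 log units; that floor lies within the scatter), and likewise an at least 1.3-fold higher number from compound 1 to compound 4 (0.12 log units; that floor lies within the scatter), so no real loss beyond the scatter is shown, but no gain in inhibition appears either, even with a different halogen under a different name than the chloro and bromo pair. The wider comparison does sharpen, with an at least 10-fold higher number from compound 2 to compound 4 (1.01 log units; beyond the scatter), which leaves compound 2 as the only one of the four with a clearly lower number and the three compounds carrying the longer carbamoyl-amino form all far from it.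

Going by these compounds, how much of that gap belongs to the longer form and how much to the aryl group stays open, as 3-fluorophenyl appears only in the longer form and 4-fluorophenyl only in the shorter one. On these data alone, whether any group on this nitrogen could bring the longer form closer to compound 2 also stays open, for instance a plain phenyl, a pyridyl ring or an aryl group bearing a carboxylic acid.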